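Spiro hydantoin amides: chain-end swap to a hydroxyl

The source may hold more compounds than are shown below. What is called first, only, known or untested is meant among the compounds shown, and "the series" means these compounds.

Measured compounds:
- compound 1, `CC(C)(C)OC(=O)NCCCCNC(=O)CN1CN(c2ccccc2)C2(CCN(C(=O)c3ccc(C(C)(C)C)cc3)CC2)C1=O`: "not determined" (no result reported)
- compound 2, `COC(=O)CCCNC(=O)CN1CN(c2ccccc2)C2(CCN(C(=O)c3ccc(C4CCCCC4)cc3)CC2)C1=O`: 2500 nM

In an assay on HEK293 cells for displacement of a labelled ligand from NPC1-like intracellular cholesterol transporter 1 (Homo sapiens) (a higher number here means a weaker inhibitor, a lower number a stronger inhibitor), compound 2 gives 2500 nM. Compound 1 carries no number in this assay, so it stands nowhere on the numbers shown and gives no anchor of its own; what is known of the shared core comes from compound 2 alone, and compound 2 differs from compound 1 in more than one place, so no step between them is counted.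

Compound 3, `CC(C)(C)c1ccc(C(=O)N2CCC3(CC2)C(=O)N(CC(=O)NCCCCO)CN3c2ccccc2)cc1`, is the next compound to be measured in this assay. It differs from compound 1 in one place: hydroxy in place of (tert-butoxycarbonyl)amino on a saturated chain carbon, four bonds along the chain from an amide-type nitrogen. For the measured compounds named here, no measured pair shows this change, so its size in this assay is unknown; a step of no more than the usual scatter, in either direction, is expected.

For compound 3 the estimated value in this assay is 3000 nM, with an expected range from 800 nM to 12000 nM.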

Compound 3, half-maximal inhibitory concentration: 19200 nM
Estimate against measurement, compound 3: 6.4-fold (0.81 log units) below; the whole stated range lies below it.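

In this assay compound 3 gives 19200 nM but no new step can be read: compound 1 has no number here, and compound 2 differs from compound 3 in more than one place. The size of the change from (tert-butoxycarbonyl)amino to hydroxy in this assay stays open, and nothing shown bears on the reason for this result.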